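This account rests on a few compounds, and the source may have more. Where it says the series, first, only, none or still open, it means among the compounds named here.

Working notes on the series.

Compound 1 `Oc1cccc(-c2cc(-c3ccccc3F)cc(-c3cccc(O)c3)n2)c1` gives 11200 nM in a functional assay on DU-145 cells (Homo sapiens) for inhibition; on this read-out higher numbers stand for weaker inhibition and lower numbers for stronger inhibition. Compound 2 `Oc1cccc(-c2cc(-c3cccc(F)c3)cc(-c3cccc(O)c3)n2)c1` carries 3-fluorophenyl in place of 2-fluorophenyl on an aromatic carbon and in this assay compound 2 gives 23800 nM, a step of a 2.1-fold higher number from compound 1 to compound 2 (0.33 log units; beyond the scatter). Compound 3 `Oc1ccc(-c2cc(-c3ccccc3F)cc(-c3ccc(O)cc3)n2)cc1` has a different core; the difference between the core of compound 1 and the core of compound 3 is not broken down here. In this assay compound 3 gives 7780 nM, the lowest of the three numbers, though its gap to compound 1 is within the scatter, so no order between compound 3 and compound 1 is claimed; its gap to compound 2 is beyond the scatter.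

Compound 4 `Oc1ccc(-c2cc(-c3cccc(F)c3)cc(-c3ccc(O)cc3)n2)cc1` is not yet measured. It differs from compound 3 by 3-fluorophenyl in place of 2-fluorophenyl on an aromatic carbon. This is the same kind of change as that from compound 1 to compound 2, but not the same: in compound 1 the place is meta to two 3-hydroxyphenyl groups, in compound 3 it is meta to two 4-hydroxyphenyl groups. The change has been seen once in measured compounds, so the expectation rests on a single step and on the assumption that the core of compound 3 responds alike.

The expected step in this assay is a 2.1-fold higher number from compound 3 to compound 4 (0.31 log units; beyond the scatter), because the same kind of change gave a 2.1-fold higher number from compound 1 to compound 2 (0.33 log units; beyond the scatter). Compound 4 is therefore estimated at 16000 nM, with a likely range from 8000 nM to 33000 nM.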

Compound 4, half-maximal inhibitory concentration: 9290 nM
Compound 4: the middle estimate sits 1.7-fold (0.24 log units) above what was measured, and the stated range covers the measured number.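

In this assay the move from 2-fluorophenyl to 3-fluorophenyl on the core of compound 3 gives a 1.2-fold higher number from compound 3 to compound 4 (0.08 log units; within the scatter) and so shows no change that can be told from the scatter. Set beside the step on the core of compound 1, the two readings cannot be separated: the same change on two cores in this assay, a 2.1-fold higher number (0.33 log units; beyond the scatter) from compound 1 to compound 2 and a 1.2-fold higher number (0.08 log units; within the scatter) from compound 3 to compound 4, 1.8-fold (0.25 log units) apart, within the scatter of two such steps. Among the compounds shown here, this shows that the change can be carried from one core to the other without a measurable difference between the two steps, but it does not show that the steps are equal, as one lies beyond the scatter and the other within it, and each core offers only a single pair.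

From the compounds shown here alone, all four compounds carry a fluorophenyl group opposite the ring nitrogen, so it remains open how either core would respond to a different group at that place, such as an aminophenyl group, a carboxylic acid or a longer alkyl chain. Going by these compounds, it also remains open whether the two hydroxyphenyl groups matter to the number in this assay, for instance whether a methoxy group in place of each hydroxyl would shift it on either core.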